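Chloro in place of hydrogen on the phenyl

This account rests on a few compounds, and the source may have more. Where it says the series, first, only, none or still open, it means among the compounds named here.

Compound 2 `C=C1C[C@]23C[C@@]1(O)CC[C@H]2c1ccc(O)c(C)c1[C@@H]3Cn1cc(-c2ccccc2)nn1` was tested in a functional assay on A549 cells (Homo sapiens) for cytotoxicity, read by MTT assay, with a stated time of 4 days; on this read-out higher numbers stand for weaker inhibition and lower numbers for stronger inhibition. There compound 2 gives only a limit of the assay, > 20000 nM. Compound 1 `C=C1C[C@]23C[C@@]1(O)CC[C@H]2c1ccc(OS(=O)(=O)c2ccc(C)cc2)c(C)c1[C@@H]3Cn1cc(-c2ccc(Cl)cc2)nn1` gives the same kind of result: in this assay compound 1 gives > 20000 nM, likewise a limit. Both readings thus sit at the limit of > 20000 nM in this assay, at which 2 of the 2 values shown sit. Compound 3 `C=C1C[C@]23C[C@@]1(O)CC[C@H]2c1ccc(O)c(C)c1[C@@H]3Cn1cc(-c2ccc(Cl)cc2)nn1` has not yet been measured. It differs from compound 2 by chloro in place of hydrogen on an aromatic carbon. No step beyond the scatter is expected, a step that the limit leaves unreadable from compound 2 to compound 3. Compound 3 is therefore expected to give about 30000 nM, between 8000 nM and 100000 nM, most probably again reported only as a limit.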

Compound 3, half-maximal inhibitory concentration: > 20000 nM
Compound 3 ended at the assay's limit; the forecaster's own chance of this, stated with the estimate: 85%; the middle value lies beyond the limit too.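

Compound 1, compound 2 and compound 3 all stand at a limit, so no step can be read from compound 2 or compound 1 to compound 3: the limit of > 20000 nM in this assay, at which 3 of the 3 values shown sit.

The compounds shown leave open whether chloro or the (4-methylphenyl)sulfonyl group changes cytotoxicity at all, as none of the three gives a number.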